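This account rests on a few compounds, and the source may have more. Where it says the series, first, only, none or still open, it means among the compounds named here.

In an ADME assay on liver (Mesocricetus auratus) for metabolic stability, using microsomes (a lower number here means slower removal, a higher number faster removal of the compound), compound 1 (`O=C(NCc1ccccc1)Nc1[nH]nc(-c2ccccn2)c1Cl`) gives > 400 mL.min-1.g-1 as a limit of the assay and not a number. Compound 2 (`O=C(Nc1[nH]nc(-c2ccccn2)c1C1CC1)c1ccccc1F`) gives > 100 mL.min-1.g-1 in this assay and this too is only a limit, so compound 2 has no exact value. Compound 3 (`COc1ccc(C(=O)Nc2[nH]nc(-c3ccccn3)c2C2CC2)cc1`) carries 4-methoxyphenyl in place of 2-fluorophenyl on a carbonyl carbon and is otherwise the same as compound 2. Going by the values given here, no measured step bears on this change, so no shift beyond the scatter is expected in this assay for it. The estimated step is a step that the limit leaves unreadable from compound 2 to compound 3 and it stays small. Compound 3 is expected at 150 mL.min-1.g-1 with an estimated range from 60 mL.min-1.g-1 to 400 mL.min-1.g-1 in this assay.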

Compound 3, intrinsic clearance in microsomes: > 100 mL.min-1.g-1
Compound 3 was reported as a limit (the forecaster's own chance of this, stated with the estimate: 55%); the middle value lies beyond the limit too.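

Going by these compounds alone, compound 2 and compound 3 are both reported only as limits in this assay, and no step between them can be read. The compounds shown leave open how large the clearance of each one actually is, and whether 4-methoxyphenyl in place of 2-fluorophenyl on a carbonyl carbon changes it at all.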